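This account rests on a few compounds, and the source may have more. Where it says the series, first, only, none or still open, it means among the compounds named here.

Two thiourea-linked compounds built on a shared core have been measured in a functional assay on NCI-H1975 cells (Homo sapiens) for antiproliferative activity, read by MTT assay, with a stated time of 72 h; on this read-out higher numbers stand for weaker inhibition and lower numbers for stronger inhibition. Compound 1, `NS(=O)(=O)c1ccc(NC(=S)Nc2ccc3ncnc(Nc4ccc(F)c(Br)c4)c3c2)cc1`, gives 9980 nM in this assay. Within the data shown here, compound 2, `NS(=O)(=O)c1ccc(NC(=S)Nc2ccc3ncnc(Nc4cccc(Cl)c4F)c3c2)cc1`, gives 25100 nM in this assay, which is the higher of the two numbers; the only step available, a 2.5-fold higher number from compound 1 to compound 2 (0.40 log units; beyond the scatter), is a modest one, lying beyond the scatter, and it shows that swapping the aryl group on the nitrogen on an aromatic ring does move the read-out. Compound 3, `Cc1cccc(Nc2ncnc3ccc(NC(=S)Nc4ccc(S(N)(=O)=O)cc4)cc23)c1`, has not yet been measured. It differs from compound 2 by 3-methylphenyl in place of 3-chloro-2-fluorophenyl on a nitrogen on an aromatic ring. Among the measured compounds shown here, the one measured step concerns a change of the same aryl group, and its size suggests that a further change of this kind may shift the number by a comparable, modest amount; no measured pair tells which direction a methyl-bearing aryl takes, so nothing beyond the scatter is firmly expected. Compound 3 is therefore estimated at 22000 nM, with a range from 7000 nM to 70000 nM, a step of a 1.1-fold lower number from compound 2 to compound 3 (0.06 log units; within the scatter) expected for this change.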

Compound 3, half-maximal inhibitory concentration: 35400 nM
Compound 3: middle estimate off by 1.6-fold (0.21 log units), on the low side; measured number inside the range.
By their numbers in this assay, from the lowest: compound 1; then compounds 2 and 3 (each within the scatter of the next).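

In this assay, putting 3-methylphenyl in place of 3-chloro-2-fluorophenyl on a nitrogen on an aromatic ring gives a 1.4-fold higher number from compound 2 to compound 3 (0.15 log units; within the scatter) and so does not separate these two aryl groups, even though one carries chlorine and fluorine and the other carries only carbon. The same 3-methylphenyl group measured against 3-bromo-4-fluorophenyl gives a 3.5-fold higher number from compound 1 to compound 3 (0.55 log units; beyond the scatter) and, together with the earlier step, this sets compound 1 apart from both compound 2 and compound 3 at this position, so among these three aryl groups only the 3-bromo-4-fluorophenyl group stands out, with the lowest number. No measurement offered here explains why the read-out behaves this way at this position.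

The compounds shown leave open which part of the 3-bromo-4-fluorophenyl group goes with the lower number, as neither the bromine nor the fluorine is varied alone. They also leave open whether an unsubstituted phenyl, a 3-methoxyphenyl or a 3-ethynylphenyl group on this nitrogen would read with compound 1 or with compound 2 and compound 3.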